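The compounds below may be only part of what the source reports. "The series", "measured", "known", "first", "only" and "open" are said of these compounds alone.

Of the compounds shown here, three sharing one core have been measured in an ADME assay on microsomes from liver (Rattus norvegicus) for metabolic stability; on this read-out lower numbers stand for a shorter-lived compound and higher numbers for a longer-lived compound. Compound 1 `O=c1c(-c2ccc(F)cc2)c[nH]c2ccnc(Nc3ccc(Oc4ccnc5cc(OCCO)ccc45)c(F)c3)c12` gives 1.51 h, compound 2 `CC(C)(O)COc1ccc2c(Oc3ccc(Nc4nccc5[nH]cc(-c6ccc(F)cc6)c(=O)c45)cc3F)ccnc2c1` gives 4.14 h, and compound 3 `CC(O)COc1ccc2c(Oc3ccc(Nc4nccc5[nH]cc(-c6ccc(F)cc6)c(=O)c45)cc3F)ccnc2c1` gives 1.42 h. Compound 3 thus stands level with compound 1, the two lying within the scatter of each other, while both lie beyond the scatter from compound 2.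

The next structure, compound 4 `COC(C)(C)COc1ccc2c(Oc3ccc(Nc4nccc5[nH]cc(-c6ccc(F)cc6)c(=O)c45)cc3F)ccnc2c1`, alters the chain of compound 3: 1-methoxy-1-methylethyl in place of 1-hydroxyethyl on a saturated chain carbon bound to an oxygen on an aromatic ring. In words, 1-methoxy-1-methylethyl comes in place of 1-hydroxyethyl, on a saturated chain carbon bound to an oxygen on an aromatic ring.

For the measured compounds named here, three measured steps bear on this change. A methyl in place of hydrogen gave a 1.1-fold lower number from compound 1 to compound 3 (0.03 log units; within the scatter), which is no real movement. The step that links the two branched chains is a 2.9-fold lower number from compound 2 to compound 3 (0.46 log units; beyond the scatter), and the step from the unbranched chain is a 2.7-fold higher number from compound 1 to compound 2 (0.44 log units; beyond the scatter). The group entering compound 4 has the same 1-methyl branch as the 1-hydroxy-1-methylethyl of compound 2, which points to a modest rise. Going by the values given here, no measured compound carries a methoxy group on this chain, so that rise is uncertain and is expected to be smaller than the full gap.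

The estimated change is a 1.9-fold higher number from compound 3 to compound 4 (0.28 log units; within the scatter). Compound 4 is expected at 2.7 h, within an estimated range of 1.2 h to 6 h.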

Compound 4, half-life: 1.45 h
Compound 4: the middle estimate sits 1.9-fold (0.27 log units) above what was measured; the range from low to high includes it.
By their numbers in this assay, from the lowest: compounds 3, 4 and 1 (each within the scatter of the next); then compound 2.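

In this assay, methyl in place of hydrogen on the oxygen of the side chain removes what set compound 2 apart (a 2.9-fold lower number from compound 2 to compound 4 (0.46 log units; beyond the scatter)), so the 1-methyl branch on a saturated chain carbon bound to an oxygen on an aromatic ring does not by itself go with the higher number, and among the four compounds only the 1-hydroxy-1-methylethyl group of compound 2 stands clear of the rest. The larger 1-methoxy-1-methylethyl group, which has no hydrogen-bond donor, leaves the number where the smaller groups put it (a 1.0-fold higher number from compound 3 to compound 4 (0.01 log units; within the scatter); a 1.0-fold lower number from compound 1 to compound 4 (0.02 log units; within the scatter)), so compound 1, compound 3 and compound 4 all lie within the scatter of one another, despite their different chains. Nothing measured here explains why only the free hydroxyl combined with this branch stands apart.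

The chains shown end only in a hydroxyl or a methoxy, so it stays open how an amine, a carboxylic acid or a longer chain would read at this place. On these data alone, it also stays open whether a methoxy on the unbranched chain of compound 1 would read level with compound 4.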